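From compound 1 to compound 4: changing the sulfur side

The source may hold more compounds than are shown below. What is called first, only, known or untested is meant among the compounds shown, and "the series" means these compounds.

Compound 1 `COc1ccccc1/C=C(/SCc1ccc(Cl)c(Cl)c1)C(=O)c1ccc(Cl)cc1`: 10000 nM
Compound 2 `Cc1ccsc1/C=C(/SCc1ccc(Cl)c(Cl)c1)C(=O)c1ccc(Cl)cc1`: 50000 nM
Compound 3 `O=C(/C(=C\c1ccccc1OCc1ccccc1)SCc1ccc(Cl)c(Cl)c1)c1ccc(Cl)cc1`: 10000 nM

All three were tested in a functional assay on DU-145 cells (Homo sapiens) for inhibition, read by trypan blue exclusion, with a stated time of 96 h; on this read-out lower numbers stand for stronger inhibition of growth and higher numbers for weaker inhibition of growth. Compound 1 stands level with compound 3, and together they hold the lowest of the three numbers.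

Compound 4 `COc1ccccc1/C=C(/SCc1ccc(F)cc1)C(=O)c1ccc(Cl)cc1` has not yet been measured. It differs from compound 1 by one change: 4-fluorophenyl in place of 3,4-dichlorophenyl on a saturated chain carbon bound to a sulfur. Neither measured step touches this group. Elsewhere on the molecule, the steps were no change at the digits printed from compound 1 to compound 3 (within the scatter) and a 5.0-fold higher number from compound 1 to compound 2 (0.70 log units; beyond the scatter). They serve only as a rough guide to size, and neither gives a firm direction. A modest change is therefore expected, with an estimated 1.5-fold higher number from compound 1 to compound 4 (0.18 log units; within the scatter). Compound 4 is expected at 15000 nM, with an estimated range of 4000 nM to 50000 nM.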

Compound 4, concentration for 50% growth inhibition: 10000 nM
The estimate for compound 4 lay 1.5-fold (0.18 log units) above the measured number, within the range that was stated.
By their numbers in this assay, from the lowest: compounds 1, 3 and 4 (each within the scatter of the next); then compound 2.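

Within the data shown here, compound 4 gives the first reading at the sulfur side of the molecule: in this assay, 4-fluorophenyl in place of 3,4-dichlorophenyl on a saturated chain carbon bound to a sulfur gives no change at the digits printed from compound 1 to compound 4 (within the scatter). For this pair, then, replacing the two chlorines with one fluorine leaves the number unmoved. Nothing measured here offers a reason for this.

Still open, as far as these compounds go, is whether an amine or a carboxylic acid on that phenyl ring would read the same. So is whether 4-fluorophenyl would match this result alongside the 3-methylthiophen-2-yl of compound 2.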